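The source may report more compounds than this note shows. Statements on the series, on what has been measured and on what is new or still open speak of the compounds shown alone.

Measured compounds in an ADME assay on S9 fraction from liver (Rattus norvegicus) for metabolic stability, read by LC-MS, using NADPH, with a stated time of 90 min, tested at 5 uM; on this read-out lower numbers stand for a less stable compound and higher numbers for a more stable compound:
- compound 1, `Cc1cc(-c2nnc(Sc3c(F)cc(C(=O)NO)cc3F)n2C)nn1C`: 30%
- compound 2, `O=C(NO)c1ccc(Cn2nnc(-c3ncccn3)n2)cc1`: 99%
- compound 3, `O=C(NO)c1cc(F)c(Cc2nnc(-c3ccncc3)s2)c(F)c1`: 32%

Compound 1 stands at the low end of these numbers. Its nearest neighbour is compound 3, whose value lies within the usual scatter of that of compound 1, so the two cannot be told apart. Compound 2 sits far above both, a gap well beyond the scatter, and is the only one of the three that comes through this assay nearly intact.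

The next compound, compound 4 `Cn1c(Sc2c(F)cc(C(=O)NO)cc2F)nnc1-c1cccs1`, keeps the core of compound 1 together with its hydroxamic acid part and differs from compound 1 in one place:

thiophen-2-yl in place of 1,5-dimethyl-1H-pyrazol-3-yl on an aromatic carbon

Within the data shown here, no pair of measured compounds shows the effect of this kind of change, so there is no step to lean on. The two low values of compound 1 and compound 3 share the difluorinated hydroxamic acid part that compound 4 also carries, and nothing in the data points to the change as a route to the high number seen for compound 2. The step is therefore expected to be small, a number 5 percentage points lower from compound 1 to compound 4 (within the scatter), most likely within the scatter and, if anything, tending slightly downward. For compound 4 the value in this assay is estimated at 25%, with a range from 8% to 50%.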

Compound 4, percent of the compound remaining: 71%
Compound 4: middle estimate off by 46 percentage points, on the low side, outside the stated range (above it).
By their numbers in this assay, from the lowest: compounds 1 and 3 (each within the scatter of the next); then compound 4; then compound 2.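

In this assay, among these compounds, thiophen-2-yl in place of 1,5-dimethyl-1H-pyrazol-3-yl gives a number 41 percentage points higher from compound 1 to compound 4 (beyond the scatter), the first readable step, and it shows that the group on this aromatic carbon of the five-membered aromatic ring with 3 nitrogen can by itself move the read-out by more than the scatter. The difluorinated hydroxamic acid part and the rest of the core stay the same across this pair, yet compound 4 reaches 71% with them, so in this pair that shared part does not fix the number at a low level. Nothing measured here bears on what lies behind the step.

From the compounds shown here alone, a single pair cannot separate the entry of thiophen-2-yl from the departure of 1,5-dimethyl-1H-pyrazol-3-yl, so it remains open which of the two accounts for the step, and whether it carries over to other cores. Also open, going by these compounds, is where phenyl, furan-2-yl or a small amine such as dimethylamino on this same carbon would fall on this read-out, relative to the pair.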